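The compounds below may be only part of what the source reports. "The series", "measured", "known", "first", "only" and "open" are said of these compounds alone.

Compound 2 `CC1(C)CC(NC(=O)Nc2cccc(Cl)c2)c2cc(Cl)ccc2O1` was examined in a functional assay (aorta) with Rattus norvegicus as the target; on this read-out higher numbers stand for an effect only at larger amounts of compound and lower numbers for an effect already at smaller amounts. In this assay compound 2 gives > 30000 nM, which is a limit of the assay and not a number. Compound 1 `Cc1cccc(NC(=O)NC2CC(C)(C)Oc3ccc(Br)cc32)c1` comes from the same series. In this assay compound 1 gives > 10000 nM, again a limit rather than a number. Going by the values given here, compound 2 thus stands at a limit, as does the one further value shown. Compound 3 `CC1(C)CC(NC(=O)Nc2cccc(Cl)c2)c2cc(Br)ccc2O1` differs from compound 2 by bromo in place of chloro on an aromatic carbon. Among the compounds with values here, no measured step between compounds exists. Compound 3 is expected to remain beyond the reach of this assay, so the step from compound 2 to compound 3 is estimated as a number no higher from compound 2 to compound 3 (the limit leaves the size open), no change beyond the scatter. Compound 3 is estimated at 30000 nM, within 10000 nM to 100000 nM.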

Compound 3, half-maximal effective concentration: > 30000 nM
Compound 3 was reported as a limit; the forecaster's own chance of this, stated with the estimate: 85%; the middle value lies on the limit itself.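

Going by these compounds alone, compound 1, compound 2 and compound 3 are all reported as limits rather than numbers, so no step from compound 1 or compound 2 to compound 3 can be read. The compounds shown leave open where any of the three actually lies, and whether either halogen swap changes anything.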